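A few compounds are considered here, and "the series" means these few. Any claim that something is new, unique, unknown or untested is made for them only; others in the source may bear on it.

Measured so far in an assay for inhibition of acyl-CoA (8-3)-desaturase (Homo sapiens); on this read-out higher numbers stand for weaker inhibition and lower numbers for stronger inhibition:
compound 1, `Fc1ccc2[nH]nc(Nc3cccc(Cl)c3)c2c1`: 58 nM
compound 2, `Cc1ccc2[nH]nc(Nc3cccc(Cl)c3)c2c1`: 6 nM
compound 3, `FC(F)(F)c1ccc2[nH]nc(Nc3cccc(Cl)c3)c2c1`: 254 nM

Compound 3 holds the highest number of the three. The step of a 4.4-fold higher number from compound 1 to compound 3 (0.64 log units; beyond the scatter) is modest, the step of a 42-fold higher number from compound 2 to compound 3 (1.63 log units; beyond the scatter) is large; the step of a 9.7-fold lower number from compound 1 to compound 2 (0.99 log units; beyond the scatter) separates the other two.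

Compound 4, `COc1ccc2[nH]nc(Nc3cccc(Cl)c3)c2c1`, carries the change (methoxy in place of trifluoromethyl on an aromatic carbon). For the measured compounds named here, no measured compound bears methoxy at this position, so nothing speaks to it directly. What bears on it indirectly: both steps into compound 3, a 4.4-fold higher number from compound 1 to compound 3 (0.64 log units; beyond the scatter) and a 42-fold higher number from compound 2 to compound 3 (1.63 log units; beyond the scatter), ran to higher numbers when trifluoromethyl entered, so the departure of trifluoromethyl is expected to run the other way. Methoxy enters with 2 heavy atoms, nearer in count to methyl and fluoro than to the 4 heavy atoms that leave. A step to a lower number is therefore expected in this assay, modest to large, written as a 13-fold lower number from compound 3 to compound 4 (1.10 log units; beyond the scatter). For compound 4 the estimate is 20 nM, with a range from 5 nM to 80 nM.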

Compound 4, half-maximal inhibitory concentration: 8 nM
Compound 4: the middle estimate sits 2.5-fold (0.40 log units) above what was measured, within the range that was stated.
By their numbers in this assay, from the lowest: compounds 2 and 4 (each within the scatter of the next); then compound 1; then compound 3.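

Methyl no longer stands alone at the low end of this assay: the step of a 1.3-fold higher number from compound 2 to compound 4 (0.12 log units; within the scatter) shows that methoxy, with its oxygen and its hydrogen-bond acceptor, cannot be told apart from methyl at this position. The gain from replacing trifluoromethyl is not tied to methyl either, as methoxy also gives a 32-fold lower number from compound 3 to compound 4 (1.50 log units; beyond the scatter) and the step from fluoro, a 7.3-fold lower number from compound 1 to compound 4 (0.86 log units; beyond the scatter), runs the same way. The compounds shown offer no evidence on why these groups differ.

Still open, as far as these compounds go, is whether the oxygen of methoxy contributes anything of its own, or whether any group in this range would match methyl. A hydroxyl, an amine or a longer chain such as ethoxy at this position would test how far the low numbers extend.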